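Hydroxy to acetoxy on compound 2: cytotoxicity working notes

This account rests on a few compounds, and the source may have more. Where it says the series, first, only, none or still open, it means among the compounds named here.

Measured so far in an ADME assay on HEK293 cells (Homo sapiens) for cytotoxicity, read by MTT assay, with a stated time of 24 h; a lower number here means a stronger inhibitor, a higher number a weaker inhibitor:
compound 1 `CCOC(=O)/C=C/c1cc(OC)c(O)c(OC)c1/C(=C/c1cc(OC)c(O)c(OC)c1)C(=O)OCC` – "not determined" (no result reported)
compound 2 `CCOC(=O)/C=C/c1ccc(O)c(/C(=C/c2ccc(O)cc2)C(=O)OCC)c1` – 12000 nM
compound 3 `CCOC(=O)C(=C\c1ccc(OC)c(OC)c1)/C(=C/c1ccc(OC)c(OC)c1)C(=O)OCC` – "not determined" (no result reported)

Going by the values given here, compound 2 carries the only number, at 12000 nM. Among the compounds with values here, compound 1 and compound 3 gave no result, so compound 2 cannot be ranked against either of them, and the series offers no measured step between compounds.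

The next compound to be measured is compound 4 `CCOC(=O)/C=C/c1ccc(O)c(/C(=C/c2ccc(OC(C)=O)cc2)C(=O)OCC)c1`. It differs from compound 2 at one place (acetyl in place of hydrogen on an oxygen on an aromatic ring), with acetyl in place of hydrogen on an oxygen on an aromatic ring, so that 4-hydroxyphenyl becomes 4-acetoxyphenyl. The rest of the structure is unchanged.

Within the data shown here, no measured pair shows what this change does in this assay, so neither direction can be favoured on the data. The working expectation is therefore no change beyond the scatter, anchored on compound 2 at 12000 nM. The expected shift is a 1.3-fold higher number from compound 2 to compound 4 (0.10 log units; within the scatter). For compound 4 the estimated value is 15000 nM, with an expected range of 5000 nM to 45000 nM. Among the measured compounds shown here, the range is kept wide because it rests on the single value of compound 2 at 12000 nM.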

Compound 4, half-maximal inhibitory concentration: 20000 nM
For compound 4 the middle estimate is 1.3-fold (0.12 log units) below the measured one, within the range that was stated.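

In this assay the series now has its first readable step, a 1.7-fold higher number from compound 2 to compound 4 (0.22 log units; within the scatter), and it places the two compounds within the scatter of each other. At this position, on the oxygen of the 4-hydroxyphenyl group, the hydroxy hydrogen can therefore be exchanged for acetyl without any difference that this read-out can separate from repeat variation, so a free hydroxy here is not needed for compound 4 to read like compound 2 in this cytotoxicity assay. This is a statement about one pair on one core, and nothing available bears on the reason for the reading.

Still open, from the compounds shown here alone, is whether the same tolerance holds for a larger group on this oxygen, such as a butanoyl chain, a benzoyl group or an acyl chain carrying an amine or a carboxylic acid. Also open, going by these compounds, is whether acetyl on the other aromatic hydroxy of the shared core would read the same way, since the present pair speaks only to the 4-acetoxyphenyl side.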